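Aryl ketone variation in a small series

The source may report more compounds than this note shows. Statements on the series, on what has been measured and on what is new or still open speak of the compounds shown alone.

Measured so far:
- compound 1, `COc1cc(-c2cc(/C=C/C(=O)c3ccc(N)cc3)[nH]n2)cc(OC)c1OC`: in a functional assay on SK-MEL-5 cells (Homo sapiens) for inhibition, read by sulforhodamine B assay, with a stated time of 48 h (on this read-out lower numbers stand for stronger inhibition of growth and higher numbers for weaker inhibition of growth), compound 1 gives 3060 nM
- compound 2, `COc1ccc(-c2cc(/C=C/C(=O)c3ccc(OC)c(OC)c3)[nH]n2)cc1`: in this assay compound 2 gives 3720 nM

Among the compounds with values here, only two numbers are known. Within the data shown here, compound 1 carries the lower of the two, but compound 2 sits within the scatter of it, so the pair gives no usable order and no step between them can be drawn.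

Compound 3, `COc1cc(-c2cc(/C=C/C(=O)c3ccc(Cl)c(Cl)c3)[nH]n2)cc(OC)c1OC`, keeps the shared core of compound 1 and changes only the group on the carbonyl carbon: 3,4-dichlorophenyl in place of 4-aminophenyl on a carbonyl carbon. Among the measured compounds shown here, no measured pair shows what such a change does, so the step from compound 1 to compound 3 in this assay cannot be read off from any neighbour.

With nothing to anchor a direction, compound 3 is expected to stay close to compound 1, the step of a 1.0-fold lower number from compound 1 to compound 3 (0.01 log units; within the scatter) being no larger than the scatter. Compound 3 is therefore estimated at 3000 nM, within 900 nM to 10000 nM.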

Compound 3, concentration for total growth inhibition: 46900 nM
Beside the measured number, compound 3's estimate is 16-fold (1.19 log units) below it; the measured number lies above the stated range.
By their numbers in this assay, from the lowest: compounds 1 and 2 (each within the scatter of the next); then compound 3.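

In this assay, within the data shown here, the group on the carbonyl carbon proves not to be indifferent: 3,4-dichlorophenyl in place of 4-aminophenyl gives a 15-fold higher number from compound 1 to compound 3 (1.19 log units; beyond the scatter) on an unchanged core, the first step that lies beyond the scatter. The change swaps a ring with one hydrogen-bond donor and one acceptor for a ring with neither, so this single pair ties the higher number to the whole exchange and not to any one part of it. Nothing measured here explains the size of this step.

On these data alone, whether the step follows the loss of the amine or the arrival of the two chlorines stays open, as the pair changes both at once. A 4-chlorophenyl or 4-hydroxyphenyl group on the same carbonyl carbon would separate the two, and compound 2 differs from compound 3 in more than one place, so it cannot help.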